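This account rests on a few compounds, and the source may have more. Where it says the series, first, only, none or still open, it means among the compounds named here.

In a functional assay on MT4 cells (Homo sapiens) for cytotoxicity, read by MTT assay (a lower number here means that less compound is tolerated, a higher number that more compound is tolerated), compound 3 `Cc1c(O)nc(SCc2ccc([N+](=O)[O-])cc2)nc1Cc1c(Cl)cccc1Cl` gives > 58000 nM as a limit, not a number. Compound 1 `COc1ccc(CCSc2nc(Cc3c(Cl)cccc3Cl)c(C)c(=O)[nH]2)cc1` likewise gives only a limit at > 57000 nM in this series. Among the compounds with values here, compound 2 `Cc1c(O)nc(SCc2ccc(O)cc2)nc1Cc1c(Cl)cccc1Cl` gives 41000 nM as the one actual number. Compound 4 `CCOc1ccc(CSc2nc(O)c(C)c(Cc3c(Cl)cccc3Cl)n2)cc1` differs from compound 3 by ethoxy in place of nitro on an aromatic carbon on an aromatic carbon, para to a large group: ethoxy in place of nitro, so that 4-nitrophenyl becomes 4-ethoxyphenyl. Within the data shown here, the one measured step at that place is an at least 1.4-fold higher number from compound 2 to compound 3 (0.15 log units; that floor lies within the scatter) with nitro in place of hydroxy, and its floor stays within the scatter. Among the measured compounds shown here, that step is the only guide, so no change beyond the scatter is expected in this assay for the new group, in either direction. The expected step is an at least 1.2-fold lower number from compound 3 to compound 4 (0.11 log units; that floor lies within the scatter) and it is an estimate resting on a limit. Compound 4 is expected at 45000 nM within an estimated range of 18000 nM to 90000 nM and may also read only as a limit.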

Compound 4, half-maximal cytotoxic concentration: > 58000 nM
Compound 4: no number, only a limit (the forecaster's own chance of this, stated with the estimate: 55%); at least 1.2-fold (0.11 log units) between middle value and limit.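

In this assay compound 4 gives only a limit, as compound 3 does, so the step between these two cannot be read. Ethyl in place of hydrogen on the oxygen gives an at least 1.4-fold higher number from compound 2 to compound 4 (0.15 log units; that floor lies within the scatter), so the ethoxy group, like the nitro group with an at least 1.4-fold higher number from compound 2 to compound 3 (0.15 log units; that floor lies within the scatter), is not shown to separate from the hydroxy group beyond the scatter. At this place, nitro and ethoxy now read alike, both ending at the same limit: the limit of > 58000 nM in this assay, at which 2 of the 4 values shown sit.

Within the data shown here, compound 2 remains the only one with an actual number at this place, at 41000 nM, so the true size of either change stays unknown. As far as these compounds go, how an amine or a carboxylic acid at this place would read in this assay remains open.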